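Methyl to Chloro: an Expected Step Within Scatter

This account rests on a few compounds, and the source may have more. Where it says the series, first, only, none or still open, it means among the compounds named here.

Compound 3 `Cc1cccc(-n2cc(-c3ccc(NS(=O)(=O)c4c[nH]c(=O)[nH]c4=O)cc3)nn2)c1` gives 6960 nM in a functional assay on A549 cells (Homo sapiens) for antiproliferative activity, read by MTT assay, with a stated time of 24 h; on this read-out lower numbers stand for stronger inhibition and higher numbers for weaker inhibition. Within the data shown here, that number is the highest of the three measured so far, yet compound 1 `O=c1[nH]cc(S(=O)(=O)Nc2ccccc2-c2cn(-c3ccc(F)cc3)nn2)c(=O)[nH]1` with 6390 nM and compound 2 `Cc1ccccc1-n1cc(-c2cccc(NS(=O)(=O)c3c[nH]c(=O)[nH]c3=O)c2)nn1` with 5470 nM both sit within the scatter of it, so no ranking among the three can be read from these values. Compound 4 `O=c1[nH]cc(S(=O)(=O)Nc2ccc(-c3cn(-c4cccc(Cl)c4)nn3)cc2)c(=O)[nH]1` differs from compound 3 by chloro in place of methyl on an aromatic carbon. Among the measured compounds shown here, no measured pair shows this exchange, so there is no step to lean on. The expected step is a 1.1-fold lower number from compound 3 to compound 4 (0.03 log units; within the scatter), which is to say nothing beyond the scatter. In this assay compound 4 is therefore estimated at 6500 nM, with a range from 3000 nM to 14000 nM.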

Compound 4, half-maximal inhibitory concentration: 2310 nM
Estimate against measurement, compound 4: 2.8-fold (0.45 log units) above; the measured number lies below the stated range.
By their numbers in this assay, from the lowest: compound 4; then compounds 2, 1 and 3 (each within the scatter of the next).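

In this assay, chloro in place of methyl on the aromatic carbon meta to a large group gives a 3.0-fold lower number from compound 3 to compound 4 (0.48 log units; beyond the scatter). Among these compounds, this is the first step between compounds differing in one place, and it shows that this position responds to a single-atom exchange. No measurement shown here accounts for the step. On these data alone, whether an amine, a methoxy group or a carboxylic acid at this position would lower the number further remains open. So does whether the same exchange would give a similar step on another compound with the shared core.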